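Chloro Added to a Benzamide Without Measured Toxicity

A few compounds are considered here, and "the series" means these few. Any claim that something is new, unique, unknown or untested is made for them only; others in the source may bear on it.

Measured so far:
Compound 1 `Cn1c(-c2ccccc2)cnc1NC(=O)c1ccccc1`: > 100000 nM
Compound 2 `COc1ccc(-c2cnc(NC(=O)c3ccccc3OC)n2C)cc1`: > 100000 nM

In a toxicity assay on THP-1 cells (Homo sapiens) for inhibition (on this read-out lower numbers stand for higher toxicity in this test and higher numbers for lower toxicity in this test), compound 1 gives > 100000 nM, which is a limit of the assay rather than a number. Compound 2 gives > 100000 nM, also a limit. Compound 1 thus stands at the edge of what was seen, as the limit of > 100000 nM in this assay, at which 2 of the 2 values shown sit, shows. Compound 3 `Cn1c(-c2ccccc2)cnc1NC(=O)c1ccccc1Cl` differs from compound 1 by chloro in place of hydrogen on an aromatic carbon. Among the compounds with values here, with no measured step available, no change beyond the usual scatter is expected in this assay. The expected step that the limit leaves unreadable from compound 1 to compound 3 is small. Compound 3 is expected to give about 150000 nM, within a range from 60000 nM to 400000 nM, most probably reported again only as a limit.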

Compound 3, half-maximal cytotoxic concentration: > 50000 nM
Compound 3 ended at the assay's limit; the forecaster's own chance of this, stated with the estimate: 80%; the middle value lies beyond the limit too.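

Compound 1 and compound 3 both give only limits in this assay, not numbers, so the step between them cannot be read. The compounds shown leave open whether chloro in place of hydrogen changes toxicity at all.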